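Anilide variants of a fluoroquinolone-type core: nitro for amino

The source may report more compounds than this note shows. Statements on the series, on what has been measured and on what is new or still open speak of the compounds shown alone.

Measured so far:
compound 1, `CCn1cc(-c2nc3ccc([N+](=O)[O-])cc3o2)c(=O)c2cc(F)c(N3CCNC(C)C3)c(F)c21`: 900 nM
compound 2, `CCn1cc(C(=O)Nc2ccccc2N)c(=O)c2cc(F)c(N3CCNC(C)C3)c(F)c21`: 5900 nM

In a functional assay on A549 cells (Homo sapiens) for cytotoxicity, read by MTT assay (a higher number here means a weaker inhibitor, a lower number a stronger inhibitor), compound 2 gives 5900 nM, the higher of the two numbers; compound 1 gives 900 nM, and the gap between the two lies beyond the usual scatter. The two structures differ in more than one place, so their values are noted side by side without a step between them.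

Compound 3, `CCn1cc(C(=O)Nc2cccc([N+](=O)[O-])c2)c(=O)c2cc(F)c(N3CCNC(C)C3)c(F)c21`, has not yet been measured. It is the direct partner of compound 2 in this assay: 3-nitrophenyl in place of 2-aminophenyl on an amide-type nitrogen. Going by the values given here, with no measured step of this kind to lean on, only a small move toward a lower number is expected, close to the edge of the scatter, as a 2.0-fold lower number from compound 2 to compound 3 (0.29 log units; within the scatter). Compound 3 is estimated at 3000 nM, within a range from 800 nM to 12000 nM.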

Compound 3, half-maximal inhibitory concentration: 3240 nM
Compound 3: middle estimate off by 1.1-fold (0.03 log units), on the low side; the measured number falls inside the stated range.
By their numbers in this assay, from the lowest: compound 1; then compounds 3 and 2 (each within the scatter of the next).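

In this assay, going by these compounds alone, 3-nitrophenyl in place of 2-aminophenyl on an amide-type nitrogen gives a 1.8-fold lower number from compound 2 to compound 3 (0.26 log units; within the scatter), the first measured step at this position, and it shows that this exchange leaves the value unresolved from that of compound 2. Nothing measured here bears on why the two values stand so close.

The step changes both the group and its printed ring number at once, so 2-nitrophenyl or 3-aminophenyl would be needed to separate the two. From the compounds shown here alone, how a carboxylic acid on the same phenyl ring would read also remains open.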